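The source may report more compounds than this note shows. Statements on the series, on what has been measured and on what is new or still open speak of the compounds shown alone.

Measured in an ADME assay on MDCK-II cells (Chlorocebus aethiops) for permeability, read by LC-MS, in the apical to basolateral direction, with a stated time of 120 min, tested at 5 uM; a lower number here means that the compound crosses the layer more slowly, a higher number that the compound crosses the layer faster:
- compound 1 `CC[C@@H]1C(=O)N(C)c2cnc(-n3ccnc3-c3ccc(F)cc3)nc2N1[C@H]1CCOC1`: 234 nm/s
- compound 2 `CC[C@@H]1C(=O)N(C)c2cnc(-n3ccnc3-c3ccccc3)nc2N1C1CCCC1`: 114 nm/s

Compound 1, at 234 nm/s, holds the higher of the two numbers in this assay, and the gap down to compound 2, at 114 nm/s, lies just beyond the scatter. Among the measured compounds shown here, with only two values, this places compound 1 at the top of a very short series and shows little about the range the series can reach.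

The next compound is compound 3 `CC[C@@H]1C(=O)N(C)c2cnc(-n3ccnc3-c3ccc(F)cc3)nc2N1CCC(F)(F)F`, which keeps the core of compound 1 and changes one group: 3,3,3-trifluoropropyl in place of oxolan-3-yl on a nitrogen on an aromatic ring in a ring. The two measured compounds differ from each other in more than one place, so neither gives a measured step for this change, and the expectation below is a judgement with a wide range.

A modest rise in this assay is expected, one that may not clear the scatter. The expected change is a 1.3-fold higher number from compound 1 to compound 3 (0.11 log units; within the scatter). Compound 3 is estimated at 300 nm/s, with an expected range of 150 nm/s to 550 nm/s.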

Compound 3, apparent permeability in the MDCK-II assay: 158 nm/s
Beside the measured number, compound 3's estimate is 1.9-fold (0.28 log units) above it; measured number inside the range.
By their numbers in the MDCK-II assay, from the lowest: compounds 2, 3 and 1 (each within the scatter of the next, the first and the last beyond it).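

In the MDCK-II assay the exchange of oxolan-3-yl for 3,3,3-trifluoropropyl on this nitrogen gives a 1.5-fold lower number from compound 1 to compound 3 (0.17 log units; within the scatter), so a ring with a hydrogen-bond acceptor and an open chain without one sit at this position with no step beyond the scatter. In a physicochemical assay for lipophilicity (a lower number here means a more polar compound, a higher number a more lipophilic compound), compound 1 gives 2 and compound 3 gives 3.1. In the physicochemical assay the same exchange gives a number 1.10 log units higher from compound 1 to compound 3 (beyond the scatter), and for this one pair a shift of that size comes with no permeability step beyond the scatter: the measured partition coefficient of compound 1, 2, and of compound 3, 3.1, a number 1.10 log units higher (beyond the scatter). Compound 1 and compound 2 differ in more than one place, so this pair supplies the only measured step at this position among the compounds shown.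

A single pair cannot show whether permeability and lipophilicity stay uncoupled at this nitrogen across other groups, and the step says nothing about how the oxolan-3-yl stereocentre contributes. An open question is how a group of another kind on the same nitrogen, such as an amine, a carboxylic acid or a longer chain, would read in the MDCK-II assay and in the physicochemical assay against the core of compound 1.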